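Isopropyl on the Nitrogen: Expected Cytotoxicity of Compound 4

This account rests on a few compounds, and the source may have more. Where it says the series, first, only, none or still open, it means among the compounds named here.

Compound 1 `CC(C)NC(=N)c1ccc2cc(-c3cccc(OCCCCOc4ccccc4)c3)oc2c1`: 46500 nM
Compound 2 `CC(C)NC(=N)c1ccc2cc(-c3cccc(OCCCCCOc4ccccc4)c3)oc2c1`: 20100 nM
Compound 3 `N=C(N)c1ccc2cc(-c3cccc(OCCCCCCOc4ccccc4)c3)oc2c1`: 4300 nM

In an ADME assay on L6 cells (Rattus norvegicus) for cytotoxicity, read by resazurin assay, with a stated time of 70 h (a higher number here means a weaker inhibitor, a lower number a stronger inhibitor), compound 3 gives the lowest of the three numbers; compound 2 stands a clear step above it, and compound 1 further still. Compound 4 `CC(C)NC(=N)c1ccc2cc(-c3cccc(OCCCCCCOc4ccccc4)c3)oc2c1` differs from compound 3 by isopropyl in place of hydrogen on an amine nitrogen. Among the measured compounds shown here, no measured pair isolates that change. For the measured compounds named here, the only single-place step, a 2.3-fold lower number from compound 1 to compound 2 (0.36 log units; beyond the scatter), concerns the chain, and compound 2 differs from compound 3 both in the chain and at the nitrogen. The chain change on its own is shown by a 2.3-fold lower number from compound 1 to compound 2 (0.36 log units; beyond the scatter). The part of the gap between compound 2 and compound 3 that this step does not cover is then taken to go with the change at the nitrogen, and it points to a modest rise in the number when isopropyl enters. Compound 4 is therefore expected to show a 2.1-fold higher number from compound 3 to compound 4 (0.32 log units; beyond the scatter), estimated at 9000 nM, within 4000 nM to 20000 nM.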

Compound 4, half-maximal inhibitory concentration: 10100 nM
Compound 4: middle estimate off by 1.1-fold (0.05 log units), on the low side; the range from low to high includes it.
By their numbers in this assay, from the lowest: compound 3; then compounds 4 and 2 (each within the scatter of the next); then compound 1.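

In this assay, among the compounds shown here, a 2.3-fold higher number from compound 3 to compound 4 (0.37 log units; beyond the scatter) gives the first direct reading of isopropyl in place of hydrogen on an amine nitrogen, with the chain held fixed. With isopropyl on that nitrogen, lengthening the chain gives a 2.0-fold lower number from compound 2 to compound 4 (0.30 log units; within the scatter), a step within the scatter, while the larger chain change gives a 4.6-fold lower number from compound 1 to compound 4 (0.66 log units; beyond the scatter), a step beyond it. Nothing available explains these steps.

As far as these compounds go, whether the isopropyl step keeps its size on a shorter or longer chain remains open. So does the size of the step with methyl or ethyl on the same nitrogen.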